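Propyl for phenyl on the core of compound 1

A few compounds are considered here, and "the series" means these few. Any claim that something is new, unique, unknown or untested is made for them only; others in the source may bear on it.

Compound 1 `Cn1ncc2c(-c3ccccc3)cc(NNC(=O)Nc3cc(Cl)nc(Cl)c3)nc21` is the reference point of this set. In an assay on isolated protein for binding affinity to sphingosine 1-phosphate receptor 2 (Homo sapiens), read by surface plasmon resonance (on this read-out higher numbers stand for weaker binding and lower numbers for tighter binding), compound 1 gives 1020 nM, the second highest of the three numbers. Compound 3 `Cn1nc(C(F)(F)F)c2c(-c3ccccc3)cc(NNC(=O)Nc3cc(Cl)nc(Cl)c3)nc21` stands nearest: in this assay compound 3 gives 940 nM, and the step of a 1.1-fold lower number from compound 1 to compound 3 (0.04 log units; within the scatter) arises from trifluoromethyl in place of hydrogen on an aromatic carbon. Compound 2 `CCN(CC)c1cc(NC(=O)NNc2cc(-c3ccc(F)cc3)c3cnn(C)c3n2)cc(Cl)n1` stands furthest; in this assay compound 2 gives 3150 nM, and it differs from compound 1 in more than one place, so only the two values themselves can be compared.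

Compound 4 `CCCc1cc(NNC(=O)Nc2cc(Cl)nc(Cl)c2)nc2c1cnn2C` is not yet measured. It differs from compound 1 as follows: propyl in place of phenyl on an aromatic carbon. For the measured compounds named here, none of the measured steps bears on this change: the one single-point step, from compound 1 to compound 3, concerns a trifluoromethyl substituent and says nothing about exchanging a phenyl ring for a propyl chain. The direction of this step is therefore open, and only a wide range can be given. A moderate loss is taken as the working guess, so for compound 4 the expected step is a 1.5-fold higher number from compound 1 to compound 4 (0.17 log units; within the scatter). Compound 4 is accordingly estimated at 1500 nM in this assay, with a range from 500 nM to 5000 nM.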

Compound 4, dissociation constant: 1400 nM
Compound 4: middle estimate off by 1.1-fold (0.03 log units), on the high side; the measured number falls inside the stated range.
By their numbers in this assay, from the lowest: compounds 3, 1 and 4 (each within the scatter of the next); then compound 2.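

In this assay, for the compounds shown here, the exchange of phenyl for propyl gives a 1.4-fold higher number from compound 1 to compound 4 (0.14 log units; within the scatter) and is the first single-point step read at this position, an aromatic carbon opposite the ring nitrogen; the trifluoromethyl step among the earlier compounds concerned a different place. Within this one pair, an aromatic ring at this position is therefore not needed to stay within the scatter of compound 1, since propyl, with no ring and 3 heavy atoms, serves as well as phenyl with its 6 heavy atoms. Nothing available explains why the two groups read alike.

As far as these compounds go, whether this tolerance extends beyond propyl remains open: a longer chain, a cyclohexyl ring, an amine or a carboxylic acid at this position could show where it ends, and a single pair gives no limit in either direction. Also open, from the compounds shown here alone, is whether propyl at this position and trifluoromethyl on the shared core would combine without a step beyond the scatter, as each has been read only singly against compound 1.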